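Fluoro in Place of Propyl on a Retinoid Core

This account rests on a few compounds, and the source may have more. Where it says the series, first, only, none or still open, it means among the compounds named here.

Compound 2 `CCCc1cc2c(cc1C(=O)c1ccc(C(=O)O)cc1)C(C)(C)CCC2(C)C` stands at an assay limit rather than at a measured number. In an assay on CV-1 cells with retinoic acid receptor gamma (Homo sapiens) as the target (on this read-out lower numbers stand for an effect already at smaller amounts and higher numbers for an effect only at larger amounts of compound), compound 2 gives > 10000 nM, which is a limit. Compound 1 `CCc1cc2c(cc1C(=O)c1ccc(C(=O)O)cc1)C(C)(C)CCC2(C)C` likewise gives > 10000 nM in this assay, also a limit. The step that the two limits leave unreadable from compound 1 to compound 2 therefore cannot be read, since the limit of > 10000 nM in this assay, at which 2 of the 2 values shown sit, holds both values. Compound 3 `CC1(C)CCC(C)(C)c2cc(C(=O)c3ccc(C(=O)O)cc3)c(F)cc21` differs from compound 2 by fluoro in place of propyl on an aromatic carbon. Going by the values given here, no measured step bears on this change, so its size and direction in this assay cannot be drawn from the data. Compound 3 is expected at 5000 nM, between 300 nM and 30000 nM, a step of an at least 2.0-fold lower number from compound 2 to compound 3 (0.30 log units; that floor lies within the scatter) estimated with little confidence.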

Compound 3, half-maximal effective concentration: 1020 nM
Estimate against measurement, compound 3: 4.9-fold (0.69 log units) above; the range from low to high includes it.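

Going by these compounds alone, replacing a chain with fluoro on this aromatic carbon gives the first readable number in this assay: propyl to fluoro is an at least 9.8-fold lower number from compound 2 to compound 3 (0.99 log units; beyond the scatter), and ethyl to fluoro is an at least 9.8-fold lower number from compound 1 to compound 3 (0.99 log units; beyond the scatter). Both steps are floors, and their true size may be larger. The step from ethyl to propyl still cannot be read: the limit of > 10000 nM in this assay, at which 2 of the 3 values shown sit.

The compounds shown leave open whether the lower number comes from fluoro itself or simply from losing the chain. Chloro or methoxy on this aromatic carbon would bear on that question.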